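A few compounds are considered here, and "the series" means these few. Any claim that something is new, unique, unknown or untested is made for them only; others in the source may bear on it.

In a functional assay on MCF7 cells (Homo sapiens) for inhibition, with a stated time of 48 h (on this read-out lower numbers stand for stronger inhibition and higher numbers for weaker inhibition), compound 1 (`COc1cc(Sc2c[nH]c3ccccc23)cc(OC)c1OC`) gives 34 nM, compound 2 (`COc1cc(Sc2c[nH]c3ccc(Cl)cc23)cc(OC)c1OC`) gives 77 nM and compound 3 (`COc1cc(Sc2c(C)[nH]c3ccc(Cl)cc23)cc(OC)c1OC`) gives 82 nM. Compound 2 thus lies within the scatter of compound 3 and shows a higher number than compound 1. Compound 4 (`COc1cc(Sc2c[nH]c3ccc(I)cc23)cc(OC)c1OC`), not yet measured, differs from compound 2 by iodo in place of chloro on an aromatic carbon. The closest evidence is the modest step of a 2.3-fold higher number from compound 1 to compound 2 (0.36 log units; beyond the scatter), which brought in chloro on that same carbon. The step of a 1.1-fold higher number from compound 2 to compound 3 (0.03 log units; within the scatter) concerns a methyl group on another carbon and stays within the scatter. Going by the values given here, no iodo compound has a measured value to compare. Only a small change is therefore expected, an estimated 1.2-fold higher number from compound 2 to compound 4 (0.07 log units; within the scatter). For compound 4 the estimated value is 90 nM, with an expected range of 35 nM to 220 nM.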

Compound 4, half-maximal inhibitory concentration: 68 nM
The estimate for compound 4 lay 1.3-fold (0.12 log units) above the measured number; measured number inside the range.
By their numbers in this assay, from the lowest: compounds 1, 4, 2 and 3 (each within the scatter of the next, the first and the last beyond it).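

In this assay, iodo in place of chloro on this aromatic carbon leaves the number unchanged within the scatter (a 1.1-fold lower number from compound 2 to compound 4 (0.05 log units; within the scatter)), so the two halogens read alike here. Measured against hydrogen on the same carbon, iodo gives a step at the edge of the scatter (a 2.0-fold higher number from compound 1 to compound 4 (0.30 log units; within the scatter)), and this is the second halogen compared at this position. Nothing shown gives a cause for this result. The compounds shown leave open how bromo, methoxy or an amine on this carbon would read, and whether any group there could give a lower number than hydrogen.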